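Swapping Fluoro for Cyano: Expected Cytotoxicity of Compound 3

The compounds below may be only part of what the source reports. "The series", "measured", "known", "first", "only" and "open" are said of these compounds alone.

Three compounds share one core. Compound 1 `COc1nc(-c2ccccc2F)ccc1[C@@H](c1ccccc1)[C@@](O)(CCN(C)C)c1cccc2ccccc12` has no number in a toxicity assay on HeLa cells (Homo sapiens) for cytotoxicity; on this read-out higher numbers stand for lower toxicity in this test and lower numbers for higher toxicity in this test; its entry simply reads "nd" (no result reported). Compound 2 `COc1nc(-c2ccc(F)cc2)ccc1[C@@H](c1ccccc1)[C@@](O)(CCN(C)C)c1cccc2ccccc12` was tested in this assay. For compound 2 the result is a limit of the test, > 64 ug/mL, not a measured number. Where compound 2 stands is thus set by the limit of > 64 ug/mL in this assay, at which 1 of the 2 values shown sits: one of the two entries sits at that limit, the other carries no value. Compound 3 `COc1nc(-c2ccc(C#N)cc2)ccc1[C@@H](c1ccccc1)[C@@](O)(CCN(C)C)c1cccc2ccccc12` is not yet measured. It differs from compound 2 by cyano in place of fluoro on an aromatic carbon, in words cyano in place of fluoro on an aromatic carbon. Among the measured compounds shown here, no step between measured compounds exists to lean on, so the expected change is none beyond the usual scatter, and the estimated step from compound 2 to compound 3 is a step that the limit leaves unreadable from compound 2 to compound 3. Compound 3 is therefore expected to give about 70 ug/mL, within 40 ug/mL to 150 ug/mL, with a good chance that the test again reports only a limit.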

Compound 3, half-maximal cytotoxic concentration: > 64 ug/mL
Compound 3: only a limit was reported; the forecaster's own chance of this, stated with the estimate: 70%; the middle value does not contradict the limit.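

Compound 2 and compound 3 each gave only a limit of the test, not a number, so no step between them can be read: the limit of > 64 ug/mL in this assay, at which 2 of the 3 values shown sit.

The compounds shown leave open how far beyond that limit each lies in this assay, and whether cyano in place of fluoro changes the result at all.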